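Cytotoxicity notes: isopropoxy for acetamido on the biaryl

This account rests on a few compounds, and the source may have more. Where it says the series, first, only, none or still open, it means among the compounds named here.

Measured so far in an ADME assay on HEK293 cells (Homo sapiens) for cytotoxicity, read by CellTiter-Glo and resazurin assay, with a stated time of 72 h; a lower number here means that less compound is needed, a higher number that more compound is needed for the effect:
compound 1 `CC(=O)Nc1cccc(-c2ccc(C(=O)N(Cc3cccc(OCCCCCC(=O)O)c3)C(C)C)cc2)c1` gives > 26000 nM, a limit of the assay.
compound 2 `CC(C)N(Cc1cccc(OCCCCCC(=O)O)c1)C(=O)c1ccc(-c2ccco2)cc1` gives > 26000 nM, a limit of the assay.
compound 3 `CCOC(=O)CCCCCOc1cccc(CN(C(=O)c2ccc(-c3cccc(NC(C)=O)c3)cc2)C(C)C)c1` gives > 26000 nM, a limit of the assay.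

Compound 3 therefore stands at the limit of > 26000 nM in this assay, at which 3 of the 3 values shown sit, with no number of its own. The step to compound 4 `CCOC(=O)CCCCCOc1cccc(CN(C(=O)c2ccc(-c3cccc(OC(C)C)c3)cc2)C(C)C)c1` is isopropoxy in place of acetamido on an aromatic carbon. Within the data shown here, two measured steps touch the same region: a step that the two limits leave unreadable from compound 1 to compound 2 and a step that the two limits leave unreadable from compound 1 to compound 3, both unreadable, since every value in this assay is a limit. No direction or size can be read from them. For compound 4 the expectation is that this assay again reports only a limit, so the step that the limit leaves unreadable from compound 3 to compound 4 is expected to be nothing beyond the scatter. Compound 4 is estimated at 40000 nM, between 20000 nM and 120000 nM.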

Compound 4, half-maximal effective concentration: > 26000 nM
Compound 4: no number, only a limit; the forecaster's own chance of this, stated with the estimate: 85%; the middle value lies beyond the limit too.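

No step can be read from compound 3 to compound 4, since both give only a limit: the limit of > 26000 nM in this assay, at which 4 of the 4 values shown sit.

The compounds shown leave open whether any of these changes to the shared core alters the result in this assay, and at what concentration any effect appears.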